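The compounds below may be only part of what the source reports. "The series", "measured", "known", "first", "only" and "open" are said of these compounds alone.

Series notes. Compound 1 `O=C1CS/C(=N\c2nc(-c3ccc(Cl)cc3)cs2)N1` lacks the aromatic substituent that the later compounds carry on the shared core; in a functional assay on HT-29 cells (Homo sapiens) for cytotoxicity, read by MTT assay, with a stated time of 72 h (a higher number here means a weaker inhibitor, a lower number a stronger inhibitor), compound 1 gives 8900 nM. Within the data shown here, compound 2 `CN(C)c1ccc(/C=C2\S/C(=N\c3nc(-c4ccc(Cl)cc4)cs3)NC2=O)cc1` carries a 4-(dimethylamino)phenyl group there; in this assay compound 2 gives 500 nM, the lowest of the two numbers so far, with compound 1 standing beyond the scatter above it. Compound 3 `Cc1ccc(/C=C2\S/C(=N\c3nc(-c4ccc(Cl)cc4)cs3)NC2=O)cc1` differs from compound 2 by methyl in place of dimethylamino on an aromatic carbon, the same difference read one bond further out being 4-(dimethylamino)phenyl to 4-methylphenyl. Among the measured compounds shown here, no measured pair shows this exact change, so its size can only be inferred from compound 1 and compound 2. Keeping the aromatic substituent while losing the dimethylamino is expected to move the number part of the way toward compound 1; the step expected is a 3.0-fold higher number from compound 2 to compound 3 (0.48 log units; beyond the scatter), beyond the scatter. Compound 3 is estimated at 1500 nM, with a range of 400 nM to 6000 nM.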

Compound 3, half-maximal inhibitory concentration: 500 nM
The estimate for compound 3 lay 3.0-fold (0.48 log units) above the measured number; low and high end bracket the measured number.
By their numbers in this assay, from the lowest: compounds 2 and 3 (each within the scatter of the next); then compound 1.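

In this assay, replacing dimethylamino with methyl on this aromatic carbon gives no change at the digits printed from compound 2 to compound 3 (within the scatter). The series therefore does not depend on dimethylamino at this position: the substituent can shrink to a single heavy atom and lose its nitrogen and its hydrogen-bond acceptor without a step beyond the scatter. Compound 2 and compound 3 now define a position where these two groups read alike, which the earlier pair of compounds could not show. Nothing available explains why they read alike.

Open, on these data alone, is whether this tolerance extends to groups of other kinds on the same carbon, such as a carboxylic acid, a primary amine or a longer alkyl chain. Also open, as far as these compounds go, is how an unsubstituted phenyl ring would read.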